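The source may report more compounds than this note shows. Statements on the series, on what has been measured and on what is new or still open speak of the compounds shown alone.

In an ADME assay on MT4 cells (Homo sapiens) for cytotoxicity, read by MTT assay, with a stated time of 96 h (a higher number here means that more compound is tolerated, a lower number that less compound is tolerated), compound 3 (`C/C(=N\NC(N)=O)c1ccc2c(c1)nc(-c1ccc(C(F)(F)F)cc1)n2C1CCCCC1`) offers no number to start from, as its entry reads "not determined" (no result reported). The entry for compound 2 (`C/C(=N\NC(N)=O)c1ccc2c(c1)nc(-c1ccc(Cl)cc1)n2C1CCCCC1`) is no more helpful, at "not determined" (no result reported). Compound 4 (`COc1ccc(-c2nc3cc(/C(C)=N/NC(N)=O)ccc3n2C2CCCCC2)c(OC)c1`) arises from compound 3 through one change on an aromatic carbon, 2,4-dimethoxyphenyl in place of 4-(trifluoromethyl)phenyl on an aromatic carbon. Going by the values given here, the only number available comes from compound 1 (`COc1ccc(-c2nc3cc(C(C)=O)ccc3n2C2CCCCC2)c(OC)c1`), which carries the same 2,4-dimethoxyphenyl group and gives 21000 nM. Among the compounds with values here, no measured step exists to size the change, so the expectation in this assay is that compound 4 will differ little from compound 1, which gives 21000 nM. For compound 4 the estimated value is 20000 nM, with an expected range from 7000 nM to 60000 nM.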

Compound 4, half-maximal cytotoxic concentration: 23000 nM
Beside the measured number, compound 4's estimate is 1.2-fold (0.06 log units) below it, and the stated range covers the measured number.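

In this assay, the result gives the first measured step, a 1.1-fold higher number from compound 1 to compound 4 (0.04 log units; within the scatter): with 2,4-dimethoxyphenyl held fixed, the two open-chain groups on that aromatic carbon cannot be told apart. The step from compound 3 cannot be read, as compound 3 has no number, so 2,4-dimethoxyphenyl and 4-(trifluoromethyl)phenyl remain uncompared. Nothing available explains the match between compound 1 and compound 4. Still open, from the compounds shown here alone, is whether a carboxylic acid or an amine on that aromatic carbon would read the same in this assay. Also open, going by these compounds, is whether a methyl group in place of cyclohexyl would do so.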